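Sulfonamide to glycolamide on the amine of compound 2

The compounds below may be only part of what the source reports. "The series", "measured", "known", "first", "only" and "open" are said of these compounds alone.

Compound 2 `CN(C)S(=O)(=O)NC[C@@H]1CCCc2cc(S(=O)(=O)c3cccc(F)c3)ccc21` gives 2 nM in an assay on isolated protein for displacement of a labelled ligand from 5-hydroxytryptamine receptor 6 (Homo sapiens) (a lower number here means a stronger inhibitor, a higher number a weaker inhibitor), the highest of the three numbers recorded; compound 1 `NC[C@@H]1CCCc2cc(S(=O)(=O)c3cc[nH]c3)ccc21` gives 0.316 nM and compound 3 `NCC(=O)NC[C@@H]1CCCc2cc(S(=O)(=O)c3cccc(F)c3)ccc21` gives 0.316 nM. Compound 4 `O=C(CO)NC[C@@H]1CCCc2cc(S(=O)(=O)c3cccc(F)c3)ccc21` has not been measured. It differs from compound 2 as follows: (hydroxymethyl)carbonyl in place of dimethylsulfamoyl on an amine nitrogen. For the measured compounds named here, the one step that bears on this is the exchange at the same nitrogen that produced a 6.3-fold lower number from compound 2 to compound 3 (0.80 log units; beyond the scatter), so a change of comparable direction is anticipated. A lower number is therefore expected, estimated as a 4.0-fold lower number from compound 2 to compound 4 (0.60 log units; beyond the scatter). For compound 4 the value in this assay is estimated at 0.5 nM, with a range of 0.15 nM to 2 nM.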

Compound 4, inhibition constant: 0.1 nM
The estimate for compound 4 lay 5.0-fold (0.70 log units) above the measured number, outside the stated range (below it).
By their numbers in this assay, from the lowest: compound 4; then compounds 1 and 3 (each within the scatter of the next); then compound 2.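

In this assay, this amine nitrogen gains more from (hydroxymethyl)carbonyl than the earlier acyl exchange showed, with a 20-fold lower number from compound 2 to compound 4 (1.30 log units; beyond the scatter) as the step from dimethylsulfamoyl, against a 6.3-fold lower number from compound 2 to compound 3 (0.80 log units; beyond the scatter) for the amino-bearing acyl group. The amino group on that chain is therefore not required for a low number, since hydroxy in its place gives a 3.2-fold lower number from compound 3 to compound 4 (0.50 log units; beyond the scatter) in this series. No measurement at hand explains the difference between hydroxy and amino.

Open, as far as these compounds go, is whether a methoxy group, a carboxylic acid or a longer chain in place of the hydroxy would keep numbers at this level.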